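Replacing the oxopiperidinyl amide substituent with a methylazetidinyl group

The compounds below may be only part of what the source reports. "The series", "measured", "known", "first", "only" and "open" are said of these compounds alone.

Compound 3 `CN1CC(NC(=O)c2ccncc2Nc2cc(-c3ccc4ccn(C)c4c3)c3nccnc3c2)CCC1=O` carries a 1-methyl-6-oxopiperidin-3-yl group on an amide-type nitrogen. In an assay on lysate for inhibition of 6-phosphofructo-2-kinase/fructose-2,6-bisphosphatase 3 (Homo sapiens), with stated times of 0.5 min and 45 min (on this read-out lower numbers stand for stronger inhibition and higher numbers for weaker inhibition), compound 3 gives 96500 nM, the weakest of the three measured values: compound 1 `CNC(=O)c1ccncc1Nc1cc(-c2ccc3ccn(C)c3c2)c2nccnc2c1` gives 7020 nM and compound 2 `CC(=O)N1CCCC(NC(=O)c2ccncc2Nc2cc(-c3ccc4ccn(C)c4c3)c3nccnc3c2)C1` gives 13500 nM. The step of a 14-fold higher number from compound 1 to compound 3 (1.14 log units; beyond the scatter) is large, and the step of a 7.1-fold higher number from compound 2 to compound 3 (0.85 log units; beyond the scatter) is modest, whereas a 1.9-fold higher number from compound 1 to compound 2 (0.28 log units; within the scatter) stays within the scatter.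

Compound 4 `CN1CC(NC(=O)c2ccncc2Nc2cc(-c3ccc4ccn(C)c4c3)c3nccnc3c2)C1` differs from compound 3 by 1-methylazetidin-3-yl in place of 1-methyl-6-oxopiperidin-3-yl on an amide-type nitrogen. The measured steps show that the 1-methyl-6-oxopiperidin-3-yl group of compound 3 goes with a markedly higher number than either the methyl of compound 1 or the 1-acetylpiperidin-3-yl of compound 2. Removing it and installing the smaller 1-methylazetidin-3-yl group is therefore expected to give a lower number in this assay, estimated as a 6.4-fold lower number from compound 3 to compound 4 (0.81 log units; beyond the scatter). For compound 4 the expected value in this assay is 15000 nM, with a range from 4000 nM to 60000 nM.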

Compound 4, half-maximal inhibitory concentration: 9190 nM
Beside the measured number, compound 4's estimate is 1.6-fold (0.21 log units) above it; the measured number falls inside the stated range.
By their numbers in this assay, from the lowest: compounds 1, 4 and 2 (each within the scatter of the next); then compound 3.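

In this assay, the change to the 1-methylazetidin-3-yl group gives an 11-fold lower number from compound 3 to compound 4 (1.02 log units; beyond the scatter) and so recovers the loss seen with the 1-methyl-6-oxopiperidin-3-yl group, while a 1.3-fold higher number from compound 1 to compound 4 (0.12 log units; within the scatter) and a 1.5-fold lower number from compound 2 to compound 4 (0.17 log units; within the scatter) both stay within the scatter. On this amide-type nitrogen, then, a substituent carrying a non-aromatic ring need not give a higher number than methyl, and among the four compounds only compound 3 stands apart. The compounds shown offer no measurement that explains this difference.

On these data alone, it remains open whether the azetidine needs its methyl on nitrogen, or whether an unsubstituted azetidine, a primary amine or a carboxylic acid on a longer chain would fit this place equally well. None of the compounds shows whether any group here can bring the number clearly below that of compound 1.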